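The source may hold more compounds than are shown below. What is called first, only, known or untested is meant among the compounds shown, and "the series" means these compounds.

Series notes, hydroxamic acid set.

Compound 1 `O=C(NO)c1ccc(NCc2nc(-c3ccccc3)nn2-c2ccc(Cl)cc2)cc1` and compound 2 `CCc1ccc(-c2nc(CNc3ccc(C(=O)NO)cc3)n(-c3ccccc3)n2)cc1` share the hydroxamic acid and the core, and differ in the aryl groups on the core. In an assay on Sf9 cells for inhibition of protein deacetylase HDAC6 (Homo sapiens), read by fluorescence, with a stated time of 40 min, tested at 100 nM (a higher number here means more inhibition at the concentration tested (going by the name of the read-out), a lower number less inhibition), compound 1 gives 55.4%. In this assay compound 2 gives 54.6%. The two numbers lie within the scatter of each other, so compound 2 sits level with compound 1 and nothing separates them on the numbers at hand.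

Compound 3 `O=C(NO)c1ccc(NCc2nc(-c3ccccc3)nn2-c2ccccc2)cc1` takes the step from compound 2: hydrogen in place of ethyl on an aromatic carbon, that is, 4-ethylphenyl to phenyl. Among the measured compounds shown here, no measured pair in this set shows what this change does on its own, so the size of the step is not known from the series. The expectation is a small loss of inhibition in this assay from compound 2 to compound 3, of about a number 7.6 percentage points lower from compound 2 to compound 3 (within the scatter), which is within the scatter and could as well be none. Compound 3 is estimated at 47% in this assay, with a range from 22% to 68%.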

Compound 3, a percentage reported as inhibition, at one concentration (the size of the read-out at that concentration, not a potency): 72.6%
For compound 3 the middle estimate is 25.6 percentage points below the measured one; the whole stated range lies below it.
By their numbers in this assay, from the lowest: compounds 2 and 1 (each within the scatter of the next); then compound 3.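

In this assay, the change from 4-ethylphenyl to phenyl gives a number 18 percentage points higher from compound 2 to compound 3 (beyond the scatter), and swapping the chloro for hydrogen gives a number 17.2 percentage points higher from compound 1 to compound 3 (beyond the scatter). Among the compounds shown here, compounds 1 and 2, level with each other, could not show whether either substituent matters, whereas these two steps show that each goes with less inhibition than hydrogen on its own aryl group, leaving compound 3 the highest of the three with no compound here going against that. Nothing available accounts for the size of either step.

Ethyl and chloro sit on different aryl groups of the shared core, so these compounds do not show how the two substituents compare at one place, or whether the phenyl of compound 3 would gain or lose from a methyl, a methoxy, an amine or a carboxylic acid at the place of the ethyl. The read-out also comes from a single concentration, which leaves open how far these steps would carry over to potency.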